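The source may report more compounds than this note shows. Statements on the series, on what has been measured and on what is new or still open speak of the compounds shown alone.

Working notes on the series. In a functional assay on JeKo-1 cells (Homo sapiens) for antiproliferative activity (on this read-out lower numbers stand for stronger inhibition and higher numbers for weaker inhibition), compound 1 (`Nc1ncnc2c1c(-c1ccc(NC(=O)c3ccccc3)cc1)cn2[C@H]1CCN(C[C@@H]2CO2)C1`) gives 5390 nM, while compound 2 (`Nc1ncnc2c1c(-c1ccc(Oc3ccccc3)cc1)cn2C[C@H]1CCCN1C(CO)CO`) gives 14500 nM, the higher of the two numbers and a gap beyond the scatter. Compound 3 (`Nc1ncnc2c1c(-c1ccc(Oc3ccccc3)cc1)cn2[C@H]1CCN(C[C@@H]2CO2)C1`) differs from compound 2 by 1-((oxiran-2-yl)methyl)pyrrolidin-3-yl in place of (1-(2-hydroxy-1-(hydroxymethyl)ethyl)pyrrolidin-2-yl)methyl on an aromatic nitrogen. Within the data shown here, no measured pair isolates this change. A lower number is expected in this assay, since compound 1 with the same 1-((oxiran-2-yl)methyl)pyrrolidin-3-yl gives 5390 nM. The estimated step is a 4.1-fold lower number from compound 2 to compound 3 (0.62 log units; beyond the scatter). The estimate for compound 3 is 3500 nM, with an expected range of 700 nM to 12000 nM.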

Compound 3, half-maximal inhibitory concentration: 1480 nM
Compound 3: middle estimate off by 2.4-fold (0.37 log units), on the high side; the range from low to high includes it.
By their numbers in this assay, from the lowest: compound 3; then compound 1; then compound 2.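

In this assay, 1-((oxiran-2-yl)methyl)pyrrolidin-3-yl on the aromatic nitrogen gives a 9.8-fold lower number from compound 2 to compound 3 (0.99 log units; beyond the scatter) with phenoxy held constant, so this change now has a measured pair. With that same group held constant, phenoxy in place of benzamido on the aromatic carbon gives a 3.6-fold lower number from compound 1 to compound 3 (0.56 log units; beyond the scatter), so this second place also shifts the number. Nothing at hand bears on the cause of either step.

The compounds shown leave open which part of the entering group carries the first step, since the oxirane ring and the pyrrolidine attachment change together. An acrylamide or a simple amine in place of the oxirane ring remains an open comparison.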